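Replacing the 2,6-dimethoxyphenyl group of compound 2

The compounds below may be only part of what the source reports. "The series", "measured", "known", "first", "only" and "open" are said of these compounds alone.

Compound 1 `O=C1c2ccccc2C(=O)N1CCOC(=S)N(C(=O)c1cccc(F)c1F)c1ccc(Cl)cc1`: 58000 nM
Compound 2 `COc1cccc(OC)c1C(=O)N(C(=S)OCCN1C(=O)c2ccccc2C1=O)c1ccc(Cl)cc1`: 69000 nM

In an ADME assay on MT4 cells (Homo sapiens) for cytotoxicity, read by MTT assay (a lower number here means that less compound is tolerated, a higher number that more compound is tolerated), compound 2 gives 69000 nM. Among the measured compounds shown here, the only other measured number, that of compound 1, lies within the scatter of it, so the two cannot be ranked.

Compound 3 `Cc1cc(C(=O)N(C(=S)OCCN2C(=O)c3ccccc3C2=O)c2ccc(Cl)cc2)c(C)o1` has not yet been measured. It differs from compound 2 in one place: 2,5-dimethylfuran-3-yl in place of 2,6-dimethoxyphenyl on a carbonyl carbon. Here 2,5-dimethylfuran-3-yl stands in place of 2,6-dimethoxyphenyl on a carbonyl carbon.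

For the measured compounds named here, one measured step bears on this change, an exchange on the same carbonyl carbon: a 1.2-fold higher number from compound 1 to compound 2 (0.08 log units; within the scatter). Going by the values given here, this is thin evidence, as it is a single step and no measured compound carries 2,5-dimethylfuran-3-yl. Among the compounds with values here, with a 1.2-fold higher number from compound 1 to compound 2 (0.08 log units; within the scatter) as the only guide, no step beyond the scatter is expected in this assay, and no direction can be favoured with confidence.

The estimated step is a 1.2-fold lower number from compound 2 to compound 3 (0.06 log units; within the scatter). For compound 3 the expected value is 60000 nM, with an estimated range from 28000 nM to 120000 nM.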

Compound 3, half-maximal cytotoxic concentration: 40000 nM
Estimate against measurement, compound 3: 1.5-fold (0.18 log units) above, within the range that was stated.
By their numbers in this assay, from the lowest: compounds 3, 1 and 2 (each within the scatter of the next).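

With 2,5-dimethylfuran-3-yl on the same carbonyl carbon, this position in this assay now carries a five-membered aromatic ring with 1 hetero atom, and the result is a 1.7-fold lower number from compound 2 to compound 3 (0.24 log units; within the scatter) and a 1.5-fold lower number from compound 1 to compound 3 (0.16 log units; within the scatter) as well. Both steps lie within the scatter, so compounds 1, 2 and 3 cannot be ranked, and the earlier single step between two substituted phenyl groups now extends to a different ring type. Exchanging 2,6-dimethoxyphenyl, with 10 heavy atoms and 2 hydrogen-bond acceptors, for a group with 7 heavy atoms and 1 hydrogen-bond acceptor therefore produces no readable difference in this cytotoxicity measurement, and nothing available here accounts for that.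

The compounds shown leave open whether a group of another kind on this carbonyl carbon, such as a carboxylic acid, a primary amine or a longer alkyl chain, would give a step beyond the scatter. They also leave open whether changes elsewhere on the shared core would be tolerated as evenly as those at this position.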